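Bromothiophene Isomers in a Dopamine Transporter Series

This account rests on a few compounds, and the source may have more. Where it says the series, first, only, none or still open, it means among the compounds named here.

Compound 1: `[O-][S+](Cc1nc(O)cc(C(F)(F)F)n1)C(c1ccccc1)c1ccccc1`, 40400 nM in an assay on HEK293 cells for inhibition of sodium-dependent dopamine transporter (Homo sapiens), read by scintillation counting, with stated times of 5 min and 1 min; a higher number here means a weaker inhibitor, a lower number a stronger inhibitor.
Compound 2: `[O-][S+](Cc1cc(Br)cs1)C(c1ccccc1)c1ccccc1`, 13700 nM.

Of the two measured compounds, compound 2 gives the lowest number in this assay; compound 1 sits higher than compound 2, beyond the scatter. Compound 3, `[O-][S+](Cc1csc(Br)c1)C(c1ccccc1)c1ccccc1`, has not been measured. It differs from compound 2 by 5-bromothiophen-3-yl in place of 4-bromothiophen-2-yl on a saturated chain carbon bound to a sulfur. Within the data shown here, since no step between measured compounds shows how this change plays out, the expected step of a 1.1-fold higher number from compound 2 to compound 3 (0.04 log units; within the scatter) is none beyond the scatter. Compound 3 is therefore estimated at 15000 nM, with a range from 5000 nM to 45000 nM.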

Compound 3, half-maximal inhibitory concentration: 16600 nM
Beside the measured number, compound 3's estimate is 1.1-fold (0.04 log units) below it; low and high end bracket the measured number.
By their numbers in this assay, from the lowest: compounds 2 and 3 (each within the scatter of the next); then compound 1.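

Exchanging 4-bromothiophen-2-yl for 5-bromothiophen-3-yl on a saturated chain carbon bound to a sulfur gives a 1.2-fold higher number from compound 2 to compound 3 (0.08 log units; within the scatter) in this assay and so stays within the scatter. Among these compounds, this is the first step that can be read at this position, and in this assay the two isomers cannot be told apart. Nothing available explains this result.

Still open, going by these compounds, is whether an amine or a carboxylic acid in place of the bromine would shift the number beyond the scatter. On these data alone, whether the sulfur's oxygen matters at all also remains unknown.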